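Notes on the amide nitrogen substituent in the series

The source may report more compounds than this note shows. Statements on the series, on what has been measured and on what is new or still open speak of the compounds shown alone.

Compound 3 `COCCN(Cc1cccs1)C(=O)COc1ccc(C)cc1` gives 400 nM in an assay on HEK293 cells for agonist activity at transient receptor potential cation channel subfamily M member 8 (Homo sapiens), read by fluorescence and calcium flux, with a stated time of 15 min; a lower number here means that less compound is needed, a higher number that more compound is needed for the effect. It is level with compound 2 `Cc1ccc(OCC(=O)N(C)Cc2cccs2)cc1`, which gives 400 nM; together these are the highest numbers of the three, and the nearest neighbour of compound 3 is compound 2, with no change at the digits printed from compound 2 to compound 3 (within the scatter). Furthest is compound 1 `Cc1ccc(OCC(=O)N(Cc2cccs2)c2ccccn2)cc1`, which gives 200 nM; the step from compound 1 to compound 3 is a 2.0-fold higher number from compound 1 to compound 3 (0.30 log units; within the scatter).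

Compound 4 `Cc1ccc(OCC(=O)N(Cc2cccs2)c2c[nH]nc2C)cc1` differs from compound 3 by 3-methyl-1H-pyrazol-4-yl in place of 2-methoxyethyl on an amide-type nitrogen. For the measured compounds named here, the steps that bear on this are those that exchange the substituent on the same nitrogen: a 2.0-fold higher number from compound 1 to compound 2 (0.30 log units; within the scatter) and a 2.0-fold higher number from compound 1 to compound 3 (0.30 log units; within the scatter). Both put an aromatic ring on that nitrogen at a slightly lower number than methyl or 2-methoxyethyl, yet neither step leaves the scatter. For compound 4 a similar small move toward a lower number is therefore expected, not beyond the scatter, a 1.6-fold lower number from compound 3 to compound 4 (0.20 log units; within the scatter). Compound 4 is estimated at 250 nM, with a range from 100 nM to 700 nM.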

Compound 4, half-maximal effective concentration: 0.4 nM
The estimate for compound 4 lay 630-fold (2.80 log units) above the measured number; measured number outside the range, below it.
By their numbers in this assay, from the lowest: compound 4; then compounds 1, 2 and 3 (each within the scatter of the next).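

In this assay, this position on the amide-type nitrogen turns out to be highly sensitive to the substituent: 3-methyl-1H-pyrazol-4-yl gives a large step from 2-methoxyethyl (a 1000-fold lower number from compound 3 to compound 4 (3.00 log units; beyond the scatter)) and from methyl (a 1000-fold lower number from compound 2 to compound 4 (3.00 log units; beyond the scatter)), whereas the earlier exchanges among methyl, 2-methoxyethyl and pyridin-2-yl all stayed within the scatter. An aromatic ring on this nitrogen is not enough in itself, as the exchange for pyridin-2-yl also gives a large step (a 500-fold lower number from compound 1 to compound 4 (2.70 log units; beyond the scatter)), so the identity of the ring matters. Nothing available here accounts for the size of these steps.

The compounds shown do not separate the contribution of the ring methyl from that of the ring itself; an unsubstituted 1H-pyrazol-4-yl or a 3-methylisoxazol-4-yl on the same nitrogen would bear on this. As far as these compounds go, the rest of the core is constant across all four compounds, so whether the step carries over to another core remains open.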